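Carbonyl substituent swap on the shared core

The compounds below may be only part of what the source reports. "The series", "measured", "known", "first", "only" and "open" are said of these compounds alone.

Compound 2 `C#CC(C)OC(=O)c1ccc(C(CC)(CC)c2ccc(OCCC(O)(CC)CC)c(C)c2)n1CC` carries a (1-methylprop-2-yn-1-yl)oxy group on the carbonyl carbon. In a functional assay on Caco-2 cells (Homo sapiens) for antiproliferative activity, read by MTT assay, with a stated time of 48 h (a lower number here means a stronger inhibitor, a higher number a weaker inhibitor), compound 2 reaches only a limit of the assay, > 50000 nM. Within the data shown here, compound 1 `CCN(CC)CCNC(=O)c1ccc(C(CC)(CC)c2ccc(OCCC(O)(CC)CC)c(C)c2)n1CC` gives 1630 nM in this assay, the single readable number in the set. Compound 3 `CCn1c(C(=O)Nc2ccc(OC(F)(F)F)cc2)ccc1C(CC)(CC)c1ccc(OCCC(O)(CC)CC)c(C)c1` also stops at a limit, > 50000 nM. What the series shows so far is the limit of > 50000 nM in this assay, at which 2 of the 3 values shown sit. From compound 1 the step of an at least 30-fold higher number from compound 1 to compound 2 (1.48 log units; beyond the scatter), and likewise the step of an at least 30-fold higher number from compound 1 to compound 3 (1.48 log units; beyond the scatter); the step that the two limits leave unreadable from compound 2 to compound 3.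

Compound 4 `CCn1c(C(=O)N(C)CC(=O)O)ccc1C(CC)(CC)c1ccc(OCCC(O)(CC)CC)c(C)c1` differs from compound 2 in one place: (carboxymethyl)(methyl)amino in place of (1-methylprop-2-yn-1-yl)oxy on a carbonyl carbon. Among the measured compounds shown here, the step that touches this position, from compound 1 to compound 2, was large, and the one from compound 2 to compound 3 cannot be read. Of the three groups on the carbonyl carbon measured so far, only the (2-(diethylamino)ethyl)amino group of compound 1 gives a number; the other two end at the limit. The (carboxymethyl)(methyl)amino group of compound 4 has no measured neighbour, so compound 4 is expected to stay close to the limit, with the step of an at least 1.2-fold lower number from compound 2 to compound 4 (0.09 log units; that floor lies within the scatter) expected. Compound 4 is estimated at 40000 nM, from 8000 nM to 200000 nM, and most likely reported only as a limit.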

Compound 4, half-maximal inhibitory concentration: 2740 nM
Compound 4: middle estimate off by 15-fold (1.16 log units), on the high side; the whole stated range lies above it.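

In this assay, a readable number at this position does not depend on the (2-(diethylamino)ethyl)amino group: placing (carboxymethyl)(methyl)amino on the carbonyl carbon gives an at least 18-fold lower number from compound 2 to compound 4 (1.26 log units; beyond the scatter), and against the aryl amide it gives an at least 18-fold lower number from compound 3 to compound 4 (1.26 log units; beyond the scatter). Among these compounds, the comparison with the only earlier readable compound is a 1.7-fold higher number from compound 1 to compound 4 (0.23 log units; within the scatter), so these two quite different groups cannot be told apart here, and a diethylamino end is not required for activity among the four compounds. A nitrogen on the carbonyl carbon is not sufficient, however, since compound 3 carries one and compound 2 does not, yet both remain at the limit: the limit of > 50000 nM in this assay, at which 2 of the 4 values shown sit.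

From the compounds shown here alone, whether the number for compound 4 comes from the free carboxylic acid, the methyl on the amide nitrogen or the length of the chain stays open; a methyl ester or primary amide in place of that acid, or the same acid on a longer chain, would separate these. Going by these compounds, the step from compound 2 to compound 3 cannot be read, so the order of those two also stays open.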